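Chain extension from compound 1 to compound 4

The source may report more compounds than this note shows. Statements on the series, on what has been measured and on what is new or still open speak of the compounds shown alone.

compound 1 `O=C(CCCOC(=O)c1ccc2c(c1)no[n+]2[O-])NO` gives 22200 nM
compound 2 `O=C(CCCCOC(=O)c1ccc2c(c1)no[n+]2[O-])NO` gives 24000 nM
compound 3 `O=C(CCCCCCOC(=O)c1ccc2c(c1)no[n+]2[O-])NO` gives 4970 nM
compound 4 `O=C(CCCCCCCOC(=O)c1ccc2c(c1)no[n+]2[O-])NO` is not yet measured

In a functional assay on B16 cells (Mus musculus) for inhibition, read by MTT assay, with a stated time of 48 h (on this read-out higher numbers stand for weaker inhibition and lower numbers for stronger inhibition), compound 1 sits at the high-number end, within the scatter of compound 2 and above compound 3. The change under study is 4-(hydroxycarbamoyl)butyl in place of hydroxycarbamoyl on a saturated chain carbon, three bonds along the chain from an oxygen next to a carbonyl group on going to compound 4. Among the compounds with values here, three measured steps bear on it: a 1.1-fold higher number from compound 1 to compound 2 (0.03 log units; within the scatter) stays within the scatter, while a 4.5-fold lower number from compound 1 to compound 3 (0.65 log units; beyond the scatter) and a 4.8-fold lower number from compound 2 to compound 3 (0.68 log units; beyond the scatter) are modest. A modest step towards a lower number is therefore expected in this assay, although no measured chain is this long. The expected step is a 4.9-fold lower number from compound 1 to compound 4 (0.69 log units; beyond the scatter) on this estimate. Compound 4 is estimated at 4500 nM with an expected range from 1800 nM to 12000 nM here.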

Compound 4, half-maximal inhibitory concentration: 7990 nM
Beside the measured number, compound 4's estimate is 1.8-fold (0.25 log units) below it; low and high end bracket the measured number.
By their numbers in this assay, from the lowest: compounds 3 and 4 (each within the scatter of the next); then compounds 1 and 2 (each within the scatter of the next).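

In this assay, the lower numbers of compound 3 persist at the 4-(hydroxycarbamoyl)butyl chain, with both shorter compounds stepping down beyond the scatter (a 2.8-fold lower number from compound 1 to compound 4 (0.44 log units; beyond the scatter); a 3.0-fold lower number from compound 2 to compound 4 (0.48 log units; beyond the scatter)). Extending the chain past compound 3 gives no change that can be told from the scatter (a 1.6-fold higher number from compound 3 to compound 4 (0.21 log units; within the scatter)). The series thus reads as two pairs, compounds 1 and 2 against compounds 3 and 4, and the step between them holds on both: the same change on two cores in this assay, a 4.5-fold lower number (0.65 log units; beyond the scatter) from compound 1 to compound 3 and a 3.0-fold lower number (0.48 log units; beyond the scatter) from compound 2 to compound 4, 1.5-fold (0.17 log units) apart, within the scatter of two such steps.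

From the compounds shown here alone, whether a longer chain keeps these numbers remains open. So does whether a carboxylic acid can replace the hydroxycarbamoyl end at these chain lengths.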